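This account rests on a few compounds, and the source may have more. Where it says the series, first, only, none or still open, it means among the compounds named here.

Working notes on the series. Compound 1 `COc1ccc(N2CCN(Cc3csc(N)c3C(=O)c3ccc(Cl)cc3)CC2)cc1` gives in an assay on CHO cells for displacement of a labelled ligand from adenosine receptor A3 (Homo sapiens), read by scintillation counting, with a stated time of 120 min, tested at 10 uM (on this read-out lower numbers stand for less inhibition and higher numbers for more inhibition at the one concentration tested (going by the name of the read-out)), a value of 0%, the lowest of the three numbers shown, with compound 2 `Nc1scc(CN2CCN(c3ccc(OC(F)(F)F)cc3)CC2)c1C(=O)c1ccc(Cl)cc1` at 1% and compound 3 `Nc1scc(CN2CCN(c3ccncc3)CC2)c1C(=O)c1ccc(Cl)cc1` at 2%. The steps are a number 1 percentage points higher from compound 1 to compound 2 (within the scatter), a number 2 percentage points higher from compound 1 to compound 3 (within the scatter) and a number 1 percentage points higher from compound 2 to compound 3 (within the scatter), all within the scatter. Compound 4 `Nc1scc(CN2CCN(c3cccc(F)c3F)CC2)c1C(=O)c1ccc(Cl)cc1` differs from compound 1 by 2,3-difluorophenyl in place of 4-methoxyphenyl on an amine nitrogen in a ring. Among the measured compounds shown here, the steps that bear on this change are the exchange on the same aryl in a number 1 percentage points higher from compound 1 to compound 2 (within the scatter) and the replacement of that aryl in a number 2 percentage points higher from compound 1 to compound 3 (within the scatter), neither beyond the scatter. No step beyond the scatter is therefore expected in this assay. For compound 4 the expected value is 1%, range -6% to 10%, an expected step of a number 1 percentage points higher from compound 1 to compound 4 (within the scatter).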

Compound 4, a percentage reported as inhibition, at one concentration (the size of the read-out at that concentration, not a potency): 0%
Compound 4: the middle estimate sits 1 percentage points above what was measured; low and high end bracket the measured number.
By their numbers in this assay, from the lowest: compounds 1, 4, 2 and 3 (each within the scatter of the next).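

In this assay, the 2,3-difluorophenyl group, with 0 hydrogen-bond acceptors where 4-methoxyphenyl has 1, gives no change at the digits printed from compound 1 to compound 4 (within the scatter). The comparisons with the other two aryl groups read the same way: a number 1 percentage points lower from compound 2 to compound 4 (within the scatter) and a number 2 percentage points lower from compound 3 to compound 4 (within the scatter). On this amine nitrogen in a ring, fluorine on the aryl ring therefore joins methoxy, trifluoromethoxy and the pyridin-4-yl ring nitrogen, with all four compounds within the scatter of one another. Going by these compounds, whether a benzyl or an acetyl group on that nitrogen would give a step beyond the scatter remains open. No measurement at hand bears on why the numbers stay this close.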